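From 4-fluorophenyl to 3,4-dichlorophenyl on the shared core

A few compounds are considered here, and "the series" means these few. Any claim that something is new, unique, unknown or untested is made for them only; others in the source may bear on it.

In a functional assay on WM1361 cells (Homo sapiens) for inhibition, read by MTT assay, with a stated time of 24 h (on this read-out lower numbers stand for stronger inhibition and higher numbers for weaker inhibition), compound 1 (`COc1cccc(N2CCN(c3c(CO)c(=O)oc4ccccc34)CC2)c1`) gives 38100 nM. Compound 2 (`O=c1oc2ccccc2c(N2CCN(c3ccc(F)cc3)CC2)c1CO`) reads > 50000 nM, which is a limit of the assay and not a number. Going by the values given here, the series so far therefore holds one number and one limit, as the limit of > 50000 nM in this assay, at which 1 of the 2 values shown sits, records, and compound 2 has no exact position.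

Compound 3 (`O=c1oc2ccccc2c(N2CCN(c3ccc(Cl)c(Cl)c3)CC2)c1CO`) keeps the shared core and carries 3,4-dichlorophenyl in place of 4-fluorophenyl on an amine nitrogen in a ring.

Among the compounds with values here, only one measured step bears on this change, as it falls at the same place: an at least 1.3-fold higher number from compound 1 to compound 2 (0.11 log units; that floor lies within the scatter), with 4-fluorophenyl in place of 3-methoxyphenyl. That step gives no direction for the new substitution, and 3,4-dichlorophenyl itself has not been measured in this series. Going by these compounds, no step beyond the scatter is therefore expected in this assay, and the direction stays open.

The expected step is an at least 1.1-fold lower number from compound 2 to compound 3 (0.04 log units; that floor lies within the scatter), which remains an estimate measured against a limit. For compound 3 the estimated value is 45000 nM, with an expected range of 20000 nM to 90000 nM.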

Compound 3, half-maximal inhibitory concentration: 42700 nM
For compound 3 the middle estimate is 1.1-fold (0.02 log units) above the measured one; the range from low to high includes it.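

A second exact number now stands for the group on an amine nitrogen in a ring in this assay and the exchange of 3-methoxyphenyl for 3,4-dichlorophenyl reads a 1.1-fold higher number from compound 1 to compound 3 (0.05 log units; within the scatter) so these two groups are not told apart on this read-out. Compound 2 reads > 50000 nM which is a limit of the assay and not a number. Against that limit, the exchange of 4-fluorophenyl for 3,4-dichlorophenyl reads an at least 1.1-fold lower number from compound 2 to compound 3 (0.06 log units; that floor lies within the scatter) and gives no direction for this change, so the reading of this position remains bounded by one limit: the limit of > 50000 nM in this assay, at which 1 of the 3 values shown sits.

Going by these compounds, whether a group of another kind on this nitrogen, such as a pyridine ring, a carboxylic acid or a chain ending in an amine, would move the number beyond the scatter remains open. The shared core is the same in all three compounds, so what a change in the core would do to these numbers is open as well.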